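A few compounds are considered here, and "the series" means these few. Any claim that something is new, unique, unknown or untested is made for them only; others in the source may bear on it.

Compound 1 `CC(=O)OCCc1c(C)[nH]c(=O)[nH]c1=O` and compound 2 `CC(=O)OCCc1c(C)nc(Cl)nc1Cl` carry the same acetoxy group on a saturated chain carbon, two bonds along the chain from an aromatic carbon, but sit on different cores; how the two cores differ is not broken down here. In a functional assay on NCI-H460 cells (Homo sapiens) for antiproliferative activity, read by MTT assay, with a stated time of 24 h (a higher number here means a weaker inhibitor, a lower number a stronger inhibitor), compound 1 gives only a limit of the assay, > 100000 nM. Compound 2 likewise gives only a limit, > 100000 nM. Compound 3 `Cc1nc(Cl)nc(Cl)c1CCCl` arises from compound 2 through the change (chloro in place of acetoxy on a saturated chain carbon, two bonds along the chain from an aromatic carbon), and in this assay compound 3 gives 3000 nM, a step of an at least 33-fold lower number from compound 2 to compound 3 (1.52 log units; beyond the scatter). Compound 4 `Cc1[nH]c(=O)[nH]c(=O)c1CCCl`, still unmeasured, differs from compound 1 by the same change, (chloro in place of acetoxy on a saturated chain carbon, two bonds along the chain from an aromatic carbon). A smaller step is expected here, because the limit of > 100000 nM in this assay, at which 2 of the 3 values shown sit, leaves the starting point of compound 1 as a limit rather than a number, so the expected step is an at least 1.6-fold lower number from compound 1 to compound 4 (0.22 log units; that floor lies within the scatter). Compound 4 is accordingly estimated at 60000 nM, and a further limit would not be surprising.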

Compound 4, half-maximal inhibitory concentration: > 100000 nM
Compound 4: only a limit was reported (the forecaster's own chance of this, stated with the estimate: 55%); middle value at least 1.6-fold (0.22 log units) from the limit.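

Among the compounds shown here, compound 1 and compound 4 both stop at a limit of the assay, so no step between them can be read: the limit of > 100000 nM in this assay, at which 3 of the 4 values shown sit. On these data alone, whether chloro in place of acetoxy changes activity on the core of compound 1, as it does on the core of compound 2, stays open.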